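Low Cytotoxicity Expected After Removing a Fluoro Group

The compounds below may be only part of what the source reports. "The series", "measured", "known", "first", "only" and "open" are said of these compounds alone.

Compound 1 `Cc1nc(C(NC(=O)C(=O)Nc2ccc(Cl)cc2)C2CCCNC2)sc1CO` in an ADME assay on MT2 cells (Homo sapiens) for cytotoxicity, read by XTT assay, with a stated time of 4 days (a lower number here means that less compound is tolerated, a higher number that more compound is tolerated), gives > 81000 nM, a limit.
Compound 2 `Cc1nc(C(NC(=O)C(=O)Nc2ccc(Cl)c(F)c2)C2CCCCN2)sc1CO` in this assay gives 77800 nM.
Compound 3 `Cc1nc(C(NC(=O)C(=O)Nc2ccc(Cl)c(F)c2)C2CCCCN2)sc1CCO` in this assay gives > 41000 nM, a limit.

Going by the values given here, compound 3 stands only at a limit in this assay, and the one step reaching it, a step that the limit leaves unreadable from compound 2 to compound 3, is likewise left unreadable by that limit. Compound 4 `Cc1nc(C(NC(=O)C(=O)Nc2ccc(Cl)cc2)C2CCCCN2)sc1CCO` differs from compound 3 by hydrogen in place of fluoro on an aromatic carbon. No measured step covers this change on its own, so nothing shown points to a shift beyond the usual scatter; the main guide is that compound 3 sits at the limit of > 41000 nM in this assay, at which 1 of the 3 values shown sits. Compound 4 is therefore expected to be tolerated to a similar degree, with a step that the limit leaves unreadable from compound 3 to compound 4 estimated as no step beyond scatter. The estimate for compound 4 is 80000 nM, ranging from 30000 nM to 200000 nM.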

Compound 4, half-maximal cytotoxic concentration: > 62000 nM
Compound 4: only a limit was reported; the forecaster's own chance of this, stated with the estimate: 70%; the middle value lies beyond the limit too.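

Compound 3 and compound 4 are both reported only as limits in this assay, and the step between them cannot be read. On these data alone, whether hydrogen in place of fluoro on an aromatic carbon changes cytotoxicity at all remains open.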